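This account rests on a few compounds, and the source may have more. Where it says the series, first, only, none or still open, it means among the compounds named here.

Compound 2 `Cc1ccc(-c2cc3c(=O)[nH]c(NC(C)(C)C)nc3s2)cc1` is tested in a toxicity assay on HepG2 cells (Homo sapiens) for cytotoxicity, read by MTT assay, with a stated time of 72 h (on this read-out higher numbers stand for lower toxicity in this test and lower numbers for higher toxicity in this test), where compound 2 gives 20500 nM. For the measured compounds named here, compound 1 `CC(C)(C)Nc1nc2sc(-c3ccccc3)cc2c(=O)[nH]1` is the only other compound measured in this assay. In this assay compound 1 gives > 12500 nM, which is a limit of the assay and not a number. Accordingly the limit of > 12500 nM in this assay, at which 1 of the 2 values shown sits, holds one of the two values shown, and compound 2 carries the only number. Going by the values given here, the single measured step is a step that the limit leaves unreadable from compound 1 to compound 2, a methyl in place of hydrogen on an aromatic carbon, and the limit leaves its size unreadable.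

Compound 3 `CC(C)(C)Nc1nc2sc(-c3ccc(Cl)cc3)cc2c(=O)[nH]1` is not yet measured. It differs from compound 2 by chloro in place of methyl on an aromatic carbon, para to a large group, so that 4-methylphenyl becomes 4-chlorophenyl. Among the compounds with values here, no measured step bears directly on this change, and the one step that exists cannot be read. The expected step in this assay is therefore a 1.0-fold lower number from compound 2 to compound 3 (0.01 log units; within the scatter), none beyond the scatter. Compound 3 is estimated in this assay at 20000 nM, with a range from 8000 nM to 50000 nM.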

Compound 3, half-maximal cytotoxic concentration: 21400 nM
Compound 3: middle estimate off by 1.1-fold (0.03 log units), on the low side; the range from low to high includes it.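

In this assay, chloro in place of methyl on an aromatic carbon, para to a large group, gives a 1.0-fold higher number from compound 2 to compound 3 (0.02 log units; within the scatter). For the compounds shown here, this is the first readable comparison at this position, and it shows that 4-methylphenyl and 4-chlorophenyl lie within the scatter of each other on this read-out, so for this one pair the identity of the group makes no measurable difference. The steps from compound 1 cannot be read, because compound 1 carries a limit of the assay and not a number: the limit of > 12500 nM in this assay, at which 1 of the 3 values shown sits.

The compounds shown therefore leave open whether either methyl or chloro differs from hydrogen at this position, and whether a group of another kind there, such as an amine, a carboxylic acid or a methoxy group, would give a step beyond the scatter. They also leave open what a different group on the nitrogen would do, such as a cyclopropyl or a longer chain in place of tert-butyl, as all three compounds share that group and the core of compound 1.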